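A few compounds are considered here, and "the series" means these few. Any claim that something is new, unique, unknown or untested is made for them only; others in the source may bear on it.

Measured compounds:
compound 1 `COc1ccc(-c2ccc3c(c2)C(=O)C(=O)N3C)cc1` — 6670 nM
compound 2 `COc1ccc(-c2ccc3c(c2)C(=O)C(=O)N3Cc2ccc(Cl)c(Cl)c2)cc1` — 990 nM
compound 3 `COc1ccc(-c2ccc3c(c2)C(=O)C(=O)N3Cc2cccc(Cl)c2)cc1` — 320 nM

In a functional assay on HepG2 cells (Homo sapiens) for antiproliferative activity, read by MTT assay, with a stated time of 48 h (on this read-out lower numbers stand for stronger inhibition and higher numbers for weaker inhibition), compound 1 gives 6670 nM, the highest of the three numbers. The nearest is compound 2, reached by a 6.7-fold lower number from compound 1 to compound 2 (0.83 log units; beyond the scatter); the furthest is compound 3, reached by a 21-fold lower number from compound 1 to compound 3 (1.32 log units; beyond the scatter). Compound 4 `COc1ccc(-c2ccc3c(c2)C(=O)C(=O)N3Cc2ccc(OC)c(OC)c2)cc1` is not yet measured. It differs from compound 1 by 3,4-dimethoxyphenyl in place of hydrogen on a saturated chain carbon bound to an amide-type nitrogen in a ring.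

Going by the values given here, two measured steps bear on this change, since both replace the same hydrogen with a substituted phenyl: a 6.7-fold lower number from compound 1 to compound 2 (0.83 log units; beyond the scatter) with 3,4-dichlorophenyl, and a 21-fold lower number from compound 1 to compound 3 (1.32 log units; beyond the scatter) with 3-chlorophenyl. Between those two, a 3.1-fold lower number from compound 2 to compound 3 (0.49 log units; beyond the scatter) shows that the number shifts with the substituents on the entering ring. Among the compounds with values here, no measured compound carries a methoxy group on that ring, so the size of the step for 3,4-dimethoxyphenyl is not fixed by the data. The expectation for compound 4 in this assay is a lower number than compound 1, beyond the scatter, of a size closer to the 3,4-dichlorophenyl case than to the 3-chlorophenyl one, with wide uncertainty. For compound 4 the estimate is 1500 nM, in the range 400 nM to 5000 nM. This estimate corresponds to the expected step of a 4.4-fold lower number from compound 1 to compound 4 (0.65 log units; beyond the scatter).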

Compound 4, half-maximal inhibitory concentration: 1350 nM
The estimate for compound 4 lay 1.1-fold (0.05 log units) above the measured number, and the stated range covers the measured number.
By their numbers in this assay, from the lowest: compound 3; then compounds 2 and 4 (each within the scatter of the next); then compound 1.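

In this assay, the lower number on replacing hydrogen at this saturated chain carbon is not confined to chloro-bearing rings: 3,4-dimethoxyphenyl gives a 4.9-fold lower number from compound 1 to compound 4 (0.69 log units; beyond the scatter). Exchanging 3,4-dichlorophenyl for 3,4-dimethoxyphenyl gives a 1.4-fold higher number from compound 2 to compound 4 (0.13 log units; within the scatter), so the two compounds cannot be separated in this assay despite the change of both ring substituents from chloro to methoxy. Compound 3 still has the lowest number of the four, with a 4.2-fold higher number from compound 3 to compound 4 (0.63 log units; beyond the scatter), so among the compounds shown the 3-chlorophenyl ring remains ahead of both rings with two substituents.

No measurement available here accounts for any of these steps. From the compounds shown here alone, it remains open whether the advantage of compound 3 follows from having a single ring substituent or from that substituent being chloro, a question that a phenyl ring with no substituent or with a single methoxy group would address. Also open, going by these compounds, is how this position responds to a ring bearing an amine or a carboxylic acid, or to a longer chain between the ring nitrogen and the phenyl ring.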